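Replacing methylsulfonyl with azetidinyloxy in the shared core

The source may hold more compounds than are shown below. What is called first, only, known or untested is meant among the compounds shown, and "the series" means these compounds.

Two compounds of the series have numbers in a functional assay on Venous blood for antagonist activity at C-X-C chemokine receptor type 3 (Homo sapiens), read by flow cytometry, with a stated time of 30 min, in the presence of a further agent that is not named here; a lower number here means a stronger inhibitor, a higher number a weaker inhibitor. Compound 1 `Cc1nc(C)n(CC(=O)N2CCN(c3sc(C(F)(F)F)nc3-c3nc4ccc(C5CCN(C)CC5)cc4[nH]3)C[C@H]2C)n1` gives 84.7 nM. For the measured compounds named here, compound 2 `Cc1nc(C)n(CC(=O)N2CCN(c3sc(C(F)(F)F)nc3-c3nc4ccc(S(C)(=O)=O)cc4[nH]3)C[C@H]2C)n1` gives 959 nM, the highest of the two numbers, and the only measured step, an 11-fold higher number from compound 1 to compound 2 (1.05 log units; beyond the scatter), separates them. Compound 3 `Cc1nc(C)n(CC(=O)N2CCN(c3sc(C(F)(F)F)nc3-c3nc4ccc(OC5CNC5)cc4[nH]3)C[C@H]2C)n1` is not yet measured and differs from compound 2 in one place: (azetidin-3-yl)oxy in place of methylsulfonyl on an aromatic carbon. Going by the values given here, the one step that bears on this change is the step from compound 1 to compound 2, where a nitrogen-containing ring on the same aromatic carbon was exchanged for methylsulfonyl and the number rose by an 11-fold higher number from compound 1 to compound 2 (1.05 log units; beyond the scatter). Compound 3 again carries a nitrogen-containing ring on that carbon, now linked through oxygen, so the expectation is a drop, estimated at a 6.4-fold lower number from compound 2 to compound 3 (0.81 log units; beyond the scatter), short of a full return to the number of compound 1. For compound 3 the estimated value is 150 nM, with a range from 50 nM to 450 nM.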

Compound 3, half-maximal inhibitory concentration: 580 nM
The estimate for compound 3 lay 3.9-fold (0.59 log units) below the measured number; the measured number lies above the stated range.
By their numbers in this assay, from the lowest: compound 1; then compounds 3 and 2 (each within the scatter of the next).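

In this assay, (azetidin-3-yl)oxy and methylsulfonyl on this aromatic carbon cannot be told apart (a 1.7-fold lower number from compound 2 to compound 3 (0.22 log units; within the scatter)). A nitrogen-containing ring at this position is therefore not sufficient by itself to reach the number of compound 1, and that gap remains beyond the scatter (a 6.8-fold higher number from compound 1 to compound 3 (0.84 log units; beyond the scatter)). No supporting data bear on why 1-methylpiperidin-4-yl and (azetidin-3-yl)oxy differ here.

The step from compound 1 to compound 3 changes ring size, the oxygen link and the methyl on nitrogen together, so the compounds shown do not assign the difference to any one of these. Going by these compounds, a (1-methylpiperidin-4-yl)oxy group or a (1-methylazetidin-3-yl)oxy group on the same carbon would separate these changes, and the effect of either group remains open.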